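The source may report more compounds than this note shows. Statements on the series, on what has been measured and on what is new or still open speak of the compounds shown alone.

Two sulfonamides set the scene. Compound 1 `CCCNc1ccc(S(=O)(=O)Nc2onc(C)c2C)cc1` carries a propylamino group on a single aromatic ring, and in an assay on VSM-A10 cells for antagonist activity at Endothelin-1 receptor (Rattus norvegicus) (on this read-out higher numbers stand for weaker inhibition and lower numbers for stronger inhibition), compound 1 gives 27000 nM. Compound 2 `Cc1noc(NS(=O)(=O)c2cccc3c(Cl)cccc23)c1C` replaces that ring with a chlorinated two-ring aromatic system, and in this assay compound 2 gives 24000 nM. Of the two numbers that of compound 2 is the smaller, yet the gap to compound 1 lies within the scatter, so the two compounds cannot be told apart on this read-out.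

Compound 3 `Cc1noc(NS(=O)(=O)c2cccc3ccccc23)c1C` is the next member. Compared with compound 2 the change is hydrogen in place of chloro on an aromatic carbon. For the measured compounds named here, no measured pair in this set shows what such a change does, so there is no step to lean on. The change is small in size, a single heavy atom removed, and no larger effect is expected in this assay than a step near the edge of the scatter, if anything toward a higher number. On that basis compound 3 is estimated at 35000 nM, within 12000 nM to 100000 nM, which would mean a step of a 1.5-fold higher number from compound 2 to compound 3 (0.16 log units; within the scatter) from the parent.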

Compound 3, half-maximal inhibitory concentration: 20000 nM
Compound 3: the middle estimate sits 1.8-fold (0.24 log units) above what was measured, within the range that was stated.
By their numbers in this assay, from the lowest: compounds 3, 2 and 1 (each within the scatter of the next).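

For the compounds shown here, the step at this position, a 1.2-fold lower number from compound 2 to compound 3 (0.08 log units; within the scatter), is the first one that can be read in this assay, and it concerns an aromatic carbon of the fused system of two rings, ortho to a fused ring and meta to a fused ring. It shows that hydrogen in place of chloro at this carbon cannot be told apart from the parent on this read-out, so compound 3 and compound 2 sit at one level and the chloro group is not required for the inhibition seen with compound 2. Nothing in the data at hand bears on what lies behind this result.

Hydrogen and chloro are the only two groups shown at this carbon, so it remains open whether an amine, a methoxy group or a carboxylic acid there would give a step beyond the scatter. Compound 1 differs from compound 2 and compound 3 in more than one place, which leaves open what a propylamino group or a longer chain would do on the two-ring system of compound 3.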